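Chloro-to-hydrogen step on the shared core, cytotoxicity

A few compounds are considered here, and "the series" means these few. Any claim that something is new, unique, unknown or untested is made for them only; others in the source may bear on it.

Measured so far:
compound 1 `ClCc1ccc(Cn2cnc3c(Cl)ncnc32)cc1` gives 91200 nM in a functional assay on SK-OV-3 cells (Homo sapiens) for cytotoxicity, read by sulforhodamine B assay, with a stated time of 48 h; on this read-out lower numbers stand for higher toxicity in this test and higher numbers for lower toxicity in this test
compound 2 `ClCc1ccc(Cn2cnc3nc(Cl)nc(Cl)c32)cc1` gives 18200 nM in this assay
compound 3 `ClCc1ccc(Cn2cnc3c(Cl)nc(Cl)nc32)cc1` gives 66100 nM in this assay

Compound 2 gives the lowest number of the three, and its gaps to compound 3 and to compound 1 are both beyond the scatter. Compound 3 and compound 1 differ in one place, (hydrogen in place of chloro on an aromatic carbon), and the step of a 1.4-fold higher number from compound 3 to compound 1 (0.14 log units; within the scatter) is within the scatter. Compound 2 and compound 3 have the same atoms joined differently; the difference between the two cores is not broken down here.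

Compound 4 `ClCc1ccc(Cn2cnc3ncnc(Cl)c32)cc1` differs from compound 2 by hydrogen in place of chloro on an aromatic carbon. The place is described in the same words as for the step from compound 3 to compound 1, so the change is the same. Because a 1.4-fold higher number from compound 3 to compound 1 (0.14 log units; within the scatter) lay within the scatter, the step from compound 2 to compound 4 is expected to be small as well, at about a 1.4-fold higher number from compound 2 to compound 4 (0.14 log units; within the scatter) in this assay. Compound 4 is therefore estimated at 25000 nM, with the range 12000 nM to 55000 nM.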

Compound 4, concentration lethal to 50% of the cells: 47900 nM
Compound 4: the middle estimate sits 1.9-fold (0.28 log units) below what was measured; measured number inside the range.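

In this assay, hydrogen in place of chloro on an aromatic carbon gives a 2.6-fold higher number from compound 2 to compound 4 (0.42 log units; beyond the scatter), a modest step. Set beside the earlier step, the same change shows no difference in size that can be told apart on the two cores: the same change on two cores in this assay, a 1.4-fold higher number (0.14 log units; within the scatter) from compound 3 to compound 1 and a 2.6-fold higher number (0.42 log units; beyond the scatter) from compound 2 to compound 4, 1.9-fold (0.28 log units) apart, within the scatter of two such steps

This supports carrying the change from one of these cores to the other as a rough guide in this assay. Within the data shown here, it does not show a firm effect common to both cores, since only the step on the core of compound 2 lies beyond the scatter, and two pairs set no rule for any further core.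

Still open, as far as these compounds go, is how the series behaves when the remaining chloro on the core gives way to an amine or a methoxy group, or when the chloromethyl group gives way to a hydroxymethyl group. Also open, from the compounds shown here alone, is whether the change carries over in the same way on cores bearing such groups.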